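Removing the ethyl from the hydroxamate-bearing carbon

This account rests on a few compounds, and the source may have more. Where it says the series, first, only, none or still open, it means among the compounds named here.

Compound 1 `CCCCC[C@@H](C(=O)NCNC(=O)c1cc2cccc(OC)c2o1)[C@H](CC)N(O)C=O` carries an ethyl on the carbon that bears the N-formyl hydroxylamine. In an assay on CHO cells for inhibition of bone morphogenetic protein 1 (Homo sapiens), with stated times of 10 min and 60 min (a lower number here means a stronger inhibitor, a higher number a weaker inhibitor), compound 1 gives only a limit, > 10000 nM, the same limit described by the limit of > 10000 nM in this assay, at which 1 of the 3 values shown sits. Compound 2 `CCCCC[C@H](CN(O)C=O)C(=O)NCNC(=O)c1ccc(-c2cccc(C(=O)O)c2)o1` and compound 3 `CCCCC[C@H](CN(O)C=O)C(=O)NCNC(=O)c1ccc(-c2ccccc2)o1` lack that ethyl; in this assay compound 2 gives 8 nM and compound 3 gives 25 nM, with a 3.1-fold higher number from compound 2 to compound 3 (0.49 log units; beyond the scatter). Compound 4 `CCCCC[C@H](CN(O)C=O)C(=O)NCNC(=O)c1cc2cccc(OC)c2o1` differs from compound 1 by hydrogen in place of ethyl on a saturated chain carbon bound to an amide-type nitrogen and a saturated chain carbon. Among the compounds with values here, no measured step isolates this change, and the one measured step concerns the far aryl group instead; yet compound 2 and compound 3 show that the core without the ethyl can be a strong inhibitor. Compound 4 is therefore expected to be far stronger than the limit seen for compound 1, an at least 160-fold lower number from compound 1 to compound 4 (2.22 log units; beyond the scatter), with an estimate of 60 nM and a likely range from 10 nM to 400 nM.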

Compound 4, half-maximal inhibitory concentration: 160 nM
Compound 4: middle estimate off by 2.7-fold (0.43 log units), on the low side, within the range that was stated.
By their numbers in this assay, from the lowest: compound 2; then compound 3; then compound 4. At a limit, above all of these: compound 1.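

In this assay hydrogen in place of ethyl on this saturated chain carbon bound to an amide-type nitrogen and a saturated chain carbon gives an at least 62-fold lower number from compound 1 to compound 4 (1.79 log units; beyond the scatter) with the rest of the structure unchanged. Within the data shown here, this is the first pair to isolate this position, and it ties the change from a limit to a measurable value to the ethyl alone. Going by these compounds, the reading for compound 1 is a limit of the assay and not a number, so the full size of the step stays unknown. The compounds shown leave open how a methyl or a longer chain on this carbon would read. They also leave open whether an ethyl there would have the same effect alongside the far aryl groups of compound 2 and compound 3.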